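A few compounds are considered here, and "the series" means these few. Any claim that something is new, unique, unknown or untested is made for them only; others in the source may bear on it.

Compound 1 `CCCCC(CC(=O)O[C@H](CC=C(C)C)C1=CC(=O)c2c(O)ccc(O)c2C1=O)OC(C)=O` carries a lipophilic ester side chain on a shared naphthoquinone-type core, and in a functional assay on DU-145 cells (Homo sapiens) for cytotoxicity, read by MTT assay (on this read-out lower numbers stand for stronger inhibition and higher numbers for weaker inhibition), compound 1 gives 67700 nM, the largest of the three numbers shown, although the other two fall within the usual scatter of it. Compound 2 `CCCC(CC(=O)O[C@H](CC=C(C)C)C1=CC(=O)c2c(O)ccc(O)c2C1=O)OC(C)=O` gives 55700 nM and compound 3 `CC(C)=CC[C@@H](OC(=O)C1CCOC1)C1=CC(=O)c2c(O)ccc(O)c2C1=O` gives 47500 nM. The change to compound 4 `CCC(O)(CC)CC(=O)O[C@H](CC=C(C)C)C1=CC(=O)c2c(O)ccc(O)c2C1=O` is 1-ethyl-1-hydroxypropyl in place of 1-acetoxypentyl on a saturated chain carbon bound to a carbonyl carbon. Among the measured compounds shown here, the steps that bear on it reshape the same side chain: a 1.2-fold lower number from compound 1 to compound 2 (0.08 log units; within the scatter), a 1.4-fold lower number from compound 1 to compound 3 (0.15 log units; within the scatter) and a 1.2-fold lower number from compound 2 to compound 3 (0.07 log units; within the scatter), none beyond the scatter. Since even the wholesale swap to an oxolanyl ring left the number essentially unchanged, the expected step is a 1.1-fold lower number from compound 1 to compound 4 (0.05 log units; within the scatter), meaning no shift beyond the scatter. Compound 4 is therefore estimated at 60000 nM, within a range from 25000 nM to 150000 nM.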

Compound 4, half-maximal inhibitory concentration: 67000 nM
Estimate against measurement, compound 4: 1.1-fold (0.05 log units) below; low and high end bracket the measured number.
By their numbers in this assay, from the lowest: compounds 3, 2, 4 and 1 (each within the scatter of the next).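

In this assay, replacing 1-acetoxypentyl with 1-ethyl-1-hydroxypropyl gives a 1.0-fold lower number from compound 1 to compound 4 (0.00 log units; within the scatter), so a side chain with 1 hydrogen-bond donor where the old one had none still leaves the number within the scatter. The other comparisons agree, with a 1.4-fold higher number from compound 3 to compound 4 (0.15 log units; within the scatter) and a 1.2-fold higher number from compound 2 to compound 4 (0.08 log units; within the scatter), so a hydroxyl-bearing chain joins the acetoxy and oxolan-3-yl groups in giving no change beyond the scatter. No supporting measurement offers an explanation for this flat result. Still open, from the compounds shown here alone, is whether an amine or a carboxylic acid on this saturated chain carbon bound to a carbonyl carbon would move the number beyond the scatter.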